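A few compounds are considered here, and "the series" means these few. Any claim that something is new, unique, unknown or untested is made for them only; others in the source may bear on it.

Working notes on the series. In a functional assay on A549 cells (Homo sapiens) for inhibition, read by MTT assay, with a stated time of 24 h (a lower number here means a stronger inhibitor, a higher number a weaker inhibitor), compound 1 `CC1(C)[C@H]2CC[C@]1(C)N(Cc1cn(-c3cccc(F)c3)nn1)C(=O)C2` gives 180 nM and compound 2 `CC1(C)[C@H]2CC[C@]1(C)N(Cc1cn(-c3cccc(C#N)c3)nn1)C(=O)C2` gives 440 nM while compound 3 `CC1(C)[C@H]2CC[C@]1(C)N(Cc1cn(-c3ccc(F)cc3)nn1)C(=O)C2` gives 230 nM on the same read-out. Compound 3 stands between the other two, with neither gap beyond the scatter (a 1.3-fold higher number from compound 1 to compound 3 (0.11 log units; within the scatter) and a 1.9-fold lower number from compound 2 to compound 3 (0.28 log units; within the scatter)). Compound 4 `CC1(C)[C@H]2CC[C@]1(C)N(Cc1cn(-c3ccc(O)cc3)nn1)C(=O)C2` has hydroxy in place of fluoro on an aromatic carbon, para to a large group (hydroxy in place of fluoro on an aromatic carbon). Among the measured compounds shown here, no measured compound carries hydroxy. The nearest evidence is the one replacement of fluoro on an aromatic carbon (a 2.4-fold higher number from compound 1 to compound 2 (0.39 log units; beyond the scatter)), a modest step beyond the scatter. A smaller step toward a higher number is expected, within the scatter (a 1.4-fold higher number from compound 3 to compound 4 (0.14 log units; within the scatter)). For compound 4 the estimated value is 320 nM with an expected range from 130 nM to 750 nM in this assay terms.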

Compound 4, half-maximal inhibitory concentration: 140 nM
The estimate for compound 4 lay 2.3-fold (0.36 log units) above the measured number; the measured number falls inside the stated range.
By their numbers in this assay, from the lowest: compounds 4, 1, 3 and 2 (each within the scatter of the next, the first and the last beyond it).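

In this assay hydroxy in place of fluoro, para to a large group, leaves the number within the scatter (a 1.6-fold lower number from compound 3 to compound 4 (0.22 log units; within the scatter)), so a hydrogen-bond donor at this place is accommodated in this series. The 4-hydroxyphenyl group also stays within the scatter of 3-fluorophenyl (a 1.3-fold lower number from compound 1 to compound 4 (0.11 log units; within the scatter)) and separates only from 3-cyanophenyl (a 3.1-fold lower number from compound 2 to compound 4 (0.50 log units; beyond the scatter)). Nothing at hand offers an explanation for these numbers. Open, from the compounds shown here alone, is whether an amine, a methoxy group or a carboxylic acid on this same aromatic carbon would stay within the scatter of hydroxy.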